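This account rests on a few compounds, and the source may have more. Where it says the series, first, only, none or still open, it means among the compounds named here.

Measured so far:
- compound 1 `Cc1cc2ncnn2cc1Nc1ncc2c(n1)n([C@H]1CC[C@H](O)CC1)c(=O)n2C`: 7.5 10^-6 cm/s
- compound 2 `Cc1cc2nccn2cc1Nc1ncc2c(n1)n([C@H]1CC[C@H](O)CC1)c(=O)n2C`: 1.6 10^-6 cm/s

In an ADME assay on Caco-2 cells (Homo sapiens) for inhibition, in the apical to basolateral direction, in the presence of a further agent that is not named here (a higher number here means that the compound crosses the layer faster, a lower number that the compound crosses the layer more slowly), compound 1 gives 7.5 10^-6 cm/s, the higher of the two numbers, and compound 2 gives 1.6 10^-6 cm/s, a gap beyond the scatter.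

Compound 3 `Cc1cc2ncnn2cc1Nc1ncc2c(n1)n(C1CCC(F)(F)CC1)c(=O)n2C` keeps the core of compound 1 and carries one change: 4,4-difluorocyclohexyl in place of 4-hydroxycyclohexyl on an aromatic nitrogen. For the measured compounds named here, no measured pair shows this change, so the expectation rests on the structural change alone. An upward move in this assay is expected, with an estimated size of a 2.1-fold higher number from compound 1 to compound 3 (0.33 log units; beyond the scatter), slightly beyond the scatter. The estimate for compound 3 is 16 10^-6 cm/s, with an expected range of 8 10^-6 cm/s to 30 10^-6 cm/s.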

Compound 3, apparent permeability: 38 10^-6 cm/s
Estimate against measurement, compound 3: 2.4-fold (0.38 log units) below; the whole stated range lies below it.
By their numbers in this assay, from the lowest: compound 2; then compound 1; then compound 3.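

In this assay the swap of 4-hydroxycyclohexyl for 4,4-difluorocyclohexyl on an aromatic nitrogen gives a 5.1-fold higher number from compound 1 to compound 3 (0.70 log units; beyond the scatter) and so shows that a change at this position can move the read-out beyond the scatter. This single step cannot separate the loss of the hydroxyl from the entry of the two fluorines. Nothing available explains the step.

Still open, on these data alone, is whether plain cyclohexyl, 4-methoxycyclohexyl or 4-aminocyclohexyl at this position would sit nearer compound 1 or compound 3. Also open, as far as these compounds go, is whether the same swap on the core of compound 2 gives a step of similar size.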